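Trading One Halogenated Phenyl Group for Another

This account rests on a few compounds, and the source may have more. Where it says the series, first, only, none or still open, it means among the compounds named here.

Going by the values given here, in a functional assay on NCI-H226 cells (Homo sapiens) for inhibition, read by MTT assay, with a stated time of 48 h, tested at 10 uM (on this read-out higher numbers stand for more inhibition at the one concentration tested (going by the name of the read-out) and lower numbers for less inhibition), compound 3 `COc1cc(NC(=O)Nc2cc(Nc3cc(I)ccc3OC)ncn2)cc(OC)c1` gives 56.7%, the highest of the three numbers measured so far. Compound 1 `COc1cc(NC(=O)Nc2cc(Nc3ccc(C(C)(C)C)cc3)ncn2)cc(OC)c1` gives 47.7%, which lies within the scatter of compound 3, while compound 2 `COc1cc(Br)ccc1Nc1cc(NC(=O)Nc2c(Cl)cccc2Cl)ncn1` gives 43%, a gap beyond the scatter. Compound 4 `COc1cc(NC(=O)Nc2cc(Nc3ccc(Br)cc3OC)ncn2)cc(OC)c1` has not yet been measured; it differs from compound 3 in one place: 4-bromo-2-methoxyphenyl in place of 5-iodo-2-methoxyphenyl on a nitrogen on an aromatic ring. Among the compounds with values here, the only measured step touching that same nitrogen is a number 9 percentage points higher from compound 1 to compound 3 (within the scatter), which stayed within the scatter even though the whole phenyl group was replaced. Exchanging one halogenated methoxyphenyl group for a closely related one is therefore expected to move this assay little, and compound 4 is estimated at 52%, between 37% and 66%, an expected step of a number 4.7 percentage points lower from compound 3 to compound 4 (within the scatter).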

Compound 4, a percentage reported as inhibition, at one concentration (the size of the read-out at that concentration, not a potency): 25.7%
Estimate against measurement, compound 4: 26.3 percentage points above; the whole stated range lies above it.
By their numbers in this assay, from the lowest: compound 4; then compounds 2, 1 and 3 (each within the scatter of the next, the first and the last beyond it).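

In this assay this nitrogen proves sensitive to small changes: 4-bromo-2-methoxyphenyl in place of 5-iodo-2-methoxyphenyl gives a number 31 percentage points lower from compound 3 to compound 4 (beyond the scatter) even though only the halogen and its place change. The same group also falls short of 4-(tert-butyl)phenyl, with a number 22 percentage points lower from compound 1 to compound 4 (beyond the scatter) on that nitrogen, and on the amide-type nitrogen 3,5-dimethoxyphenyl in place of 2,6-dichlorophenyl gives a number 17.3 percentage points lower from compound 2 to compound 4 (beyond the scatter) as well. Nothing measured here explains these drops.

Iodine gives way to bromine while the halogen's place also changes, so the compounds shown cannot say which of the two matters. An amine or a carboxylic acid in place of the halogen also remains an open case.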